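Swapping the Aryl Group on a Carbonyl Carbon

This account rests on a few compounds, and the source may have more. Where it says the series, first, only, none or still open, it means among the compounds named here.

Compound 1: `CC(C)OC(=O)Nc1c(C(O)(C(F)(F)F)C(F)(F)F)ccc2ccccc12`, 1160 nM in an assay on LtK cells with ATP-sensitive inward rectifier potassium channel 11 (Homo sapiens) as the target; a lower number here means that less compound is needed, a higher number that more compound is needed for the effect
Compound 2: `O=C(Nc1c(C(O)(C(F)(F)F)C(F)(F)F)ccc2ccccc12)c1ccccc1Cl`, 2040 nM in this assay

These two values lie within the usual scatter of each other, so compound 2 stands level with compound 1 rather than apart from it. Compound 3, `COc1ccc(C(=O)Nc2c(C(O)(C(F)(F)F)C(F)(F)F)ccc3ccccc23)cc1`, is not yet measured. Its change from compound 2 is 4-methoxyphenyl in place of 2-chlorophenyl on a carbonyl carbon. Within the data shown here, the one measured step at the same place, a 1.8-fold higher number from compound 1 to compound 2 (0.25 log units; within the scatter), moved nothing beyond the scatter. The expected step, a 1.0-fold lower number from compound 2 to compound 3 (0.01 log units; within the scatter), is therefore small with no clear direction. Compound 3 is estimated at 2000 nM, between 700 nM and 6000 nM.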

Compound 3, half-maximal effective concentration: 417 nM
Beside the measured number, compound 3's estimate is 4.8-fold (0.68 log units) above it; measured number below the stated range.
By their numbers in this assay, from the lowest: compound 3; then compounds 1 and 2 (each within the scatter of the next).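

This place on the carbonyl carbon is sensitive to the group it carries: in this assay 4-methoxyphenyl gives a 4.9-fold lower number from compound 2 to compound 3 (0.69 log units; beyond the scatter) and also a 2.8-fold lower number from compound 1 to compound 3 (0.44 log units; beyond the scatter), both beyond the scatter, whereas the earlier swap stayed within it. Having an aryl ring here is not enough for the lower number, since 2-chlorophenyl carries one too. No measurement given here accounts for this difference. Compounds with 4-chlorophenyl or 2-methoxyphenyl would separate the effect of the substituent from that of its ring position. Going by these compounds, how an amine or a carboxylic acid on this ring would fare also remains open.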